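A few compounds are considered here, and "the series" means these few. Any claim that something is new, unique, unknown or untested is made for them only; others in the source may bear on it.

Of the compounds shown here, three built on one shared core have been tested in an assay on CHO cells for displacement of a labelled ligand from Alpha-1D adrenergic receptor (Homo sapiens); on this read-out higher numbers stand for weaker inhibition and lower numbers for stronger inhibition. Compound 1 `COc1cccc(OC)c1OCCNCCOc1ccccc1OCc1ccccc1` gives 0.0676 nM. Compound 2 `COc1cccc(OC)c1OCCNCCOc1ccccc1OCc1cccc(Cl)c1` gives 0.0501 nM, and compound 3 `COc1cccc(OC)c1OCCNCCOc1ccccc1OCc1cccc([N+](=O)[O-])c1` gives 0.0631 nM. These numbers sit close together: a 1.3-fold lower number from compound 1 to compound 2 (0.13 log units; within the scatter), a 1.1-fold lower number from compound 1 to compound 3 (0.03 log units; within the scatter) and a 1.3-fold higher number from compound 2 to compound 3 (0.10 log units; within the scatter), each inside the scatter, so compound 3 is not set apart from either of the other two.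

The next compound, compound 4 `COc1cccc(OC)c1OCCNCCOc1ccccc1OCc1ccc([N+](=O)[O-])cc1`, keeps every atom of compound 3 and only joins them differently: 4-nitrophenyl in place of 3-nitrophenyl on a saturated chain carbon bound to an oxygen on an aromatic ring. For the measured compounds named here, no measured step changes where the nitro group sits; the measured steps only swap the group at one and the same spot, and none of them reached beyond the scatter. On that basis no step beyond the scatter is expected from compound 3 to compound 4 in this assay, a 1.1-fold higher number from compound 3 to compound 4 (0.05 log units; within the scatter). Compound 4 is therefore estimated at 0.07 nM, with a range from 0.025 nM to 0.2 nM.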

Compound 4, inhibition constant: 0.0501 nM
Compound 4: middle estimate off by 1.4-fold (0.15 log units), on the high side; low and high end bracket the measured number.
By their numbers in this assay, from the lowest: compounds 2, 4, 3 and 1 (each within the scatter of the next).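

Shifting the nitro group from 3-nitrophenyl to 4-nitrophenyl is the first change here that moves a group rather than swapping one, and in this assay it gives a 1.3-fold lower number from compound 3 to compound 4 (0.10 log units; within the scatter). Compound 4 also stays close to the other two compounds, with no change at the digits printed from compound 2 to compound 4 (within the scatter) and a 1.3-fold lower number from compound 1 to compound 4 (0.13 log units; within the scatter), so all the steps shown at this part of the molecule, whether a swap of group or a move of the nitro group, remain inside the scatter. Nothing available bears on why these numbers stay so close.

As far as these compounds go, whether an amine or a carboxylic acid in place of the nitro group would give a step beyond the scatter stays open. So does the effect of a longer chain at the saturated chain carbon bound to the oxygen.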